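This account rests on a few compounds, and the source may have more. Where it says the series, first, only, none or still open, it means among the compounds named here.

Measured in a functional assay on the whole organism for inhibition, with Chlorella vulgaris as the target, read by spectrophotometry, with a stated time of 4 h; on this read-out lower numbers stand for stronger inhibition and higher numbers for weaker inhibition:
compound 1 `CCCc1cnc(C(=O)/C=C/c2ccc(O)cc2)cn1` gives 514000 nM
compound 2 `CCCCc1cnc(C(=O)/C=C/c2ccc(O)cc2)cn1` gives 265000 nM
compound 3 `CC(C)Cc1cnc(C(=O)/C=C/c2ccc(O)cc2)cn1` gives 232000 nM

Compound 3 has the lowest number of the three; the value of compound 2 sits within the scatter of it, while compound 1 lies beyond it, as the step of a 2.2-fold lower number from compound 1 to compound 3 (0.35 log units; beyond the scatter) shows. Compound 4 `CC(C)c1cnc(C(=O)/C=C/c2ccc(O)cc2)cn1` carries isopropyl in place of isobutyl on an aromatic carbon. Among the compounds with values here, the steps that bear on this change are a 1.9-fold lower number from compound 1 to compound 2 (0.29 log units; within the scatter) and a 2.2-fold lower number from compound 1 to compound 3 (0.35 log units; beyond the scatter), both of which add a chain carbon and both of which lower the number in this assay. Removing a chain carbon, as here, is therefore expected to run the other way, though only a 2.2-fold lower number from compound 1 to compound 3 (0.35 log units; beyond the scatter) exceeds the scatter. Compound 4 is thus estimated at 450000 nM, with a range from 200000 nM to 1000000 nM, meaning an expected step of a 1.9-fold higher number from compound 3 to compound 4 (0.29 log units; within the scatter).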

Compound 4, half-maximal inhibitory concentration: 279000 nM
Estimate against measurement, compound 4: 1.6-fold (0.21 log units) above, and the stated range covers the measured number.
By their numbers in this assay, from the lowest: compounds 3, 2, 4 and 1 (each within the scatter of the next, the first and the last beyond it).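

On this aromatic carbon, isopropyl in place of isobutyl gives a 1.2-fold higher number from compound 3 to compound 4 (0.08 log units; within the scatter) in this assay and isopropyl in place of butyl gives a 1.1-fold higher number from compound 2 to compound 4 (0.02 log units; within the scatter) while isopropyl in place of propyl gives a 1.8-fold lower number from compound 1 to compound 4 (0.27 log units; within the scatter) so all three new steps stay within the scatter. Compound 4 thus cannot be separated from any of the other three compounds, although compound 1 and compound 3 lie beyond the scatter of each other. Nothing given here accounts for these numbers. On these data alone, whether a longer chain such as octyl would move the number further stays open. So does the effect of an amine or a carboxylic acid on this carbon.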